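The source may report more compounds than this note shows. Statements on the series, on what has been measured and on what is new or still open speak of the compounds shown alone.

Three compounds have been measured in an assay on cells for binding affinity to Neuropeptide Y receptor type 1 (Homo sapiens); on this read-out higher numbers stand for weaker inhibition and lower numbers for stronger inhibition:

Compound 1 `CCCCCOc1cc(CCc2nc(C)c(CC)s2)nc(NCc2cc(Cl)cc(NC(=O)OC(C)C)c2)c1`: 35 nM
Compound 2 `CCc1sc(CCc2cc(OC(C)C)cc(NCc3cc(Cl)cc(NC(=O)OC(C)C)c3)n2)nc1C`: 12 nM
Compound 3 `CCc1sc(CCc2cc(OC(CC)CC)cc(NCc3cc(Cl)cc(NC(=O)OC(C)C)c3)n2)nc1C`: 5.5 nM

Compound 2 stands second highest of the three in this assay. Its nearest neighbour is compound 3, reached by a 2.2-fold lower number from compound 2 to compound 3 (0.34 log units; beyond the scatter); the furthest is compound 1, from which compound 2 is reached by a 2.9-fold lower number from compound 1 to compound 2 (0.46 log units; beyond the scatter). Compound 4 `CCc1sc(CCc2cc(OC3CCCCC3)cc(NCc3cc(Cl)cc(NC(=O)OC(C)C)c3)n2)nc1C` differs from compound 2 in one place: cyclohexyl in place of isopropyl on an oxygen on an aromatic ring. The measured steps that bear on this change all concern the group on an oxygen on an aromatic ring. Both a 2.9-fold lower number from compound 1 to compound 2 (0.46 log units; beyond the scatter) and a 6.4-fold lower number from compound 1 to compound 3 (0.80 log units; beyond the scatter) show that isopropyl and pentan-3-yl give lower numbers than pentyl, and a 2.2-fold lower number from compound 2 to compound 3 (0.34 log units; beyond the scatter) shows that pentan-3-yl, with more carbons, gives a lower number than isopropyl. Cyclohexyl brings six carbons in place of three, so compound 4 is expected to move in the same direction as compound 3 did, with a 2.0-fold lower number from compound 2 to compound 4 (0.30 log units; within the scatter) in this assay. Compound 4 is therefore estimated at 6 nM, within a range from 2.5 nM to 15 nM.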

Compound 4, half-maximal inhibitory concentration: 29 nM
For compound 4 the middle estimate is 4.8-fold (0.68 log units) below the measured one; the measured number lies above the stated range.
By their numbers in this assay, from the lowest: compound 3; then compound 2; then compounds 4 and 1 (each within the scatter of the next).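

In this assay, a larger carbon group on the oxygen on the aromatic ring does not by itself lower the number: cyclohexyl gives a 2.4-fold higher number from compound 2 to compound 4 (0.38 log units; beyond the scatter), whereas pentan-3-yl had moved the same isopropyl compound the other way. The two larger groups also part clearly, with a 5.3-fold higher number from compound 3 to compound 4 (0.72 log units; beyond the scatter), so the number of carbons alone does not order this position. The advantage over pentyl seen with isopropyl and pentan-3-yl does not extend to cyclohexyl, which shows a 1.2-fold lower number from compound 1 to compound 4 (0.08 log units; within the scatter), a step within the scatter.

Nothing available here accounts for the different outcome with the ring. Whether this result is particular to cyclohexyl stays open, as the compounds shown do not tell how a smaller carbon ring such as cyclopentyl or cyclobutyl, or a tetrahydropyranyl group, would read at this oxygen.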